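Moving the methyl around a chloro-methylphenyl arm

The source may hold more compounds than are shown below. What is called first, only, known or untested is meant among the compounds shown, and "the series" means these compounds.

Compound 3 `Cc1cc(Cl)cc(-c2c(C)nn(-c3nc(-c4ccc(Cl)c(Cl)c4)c(SC(C)C)s3)c2C(=O)O)c1` gives 663 nM in a functional assay on BJAB cells (Homo sapiens) for antiproliferative activity, with a stated time of 4 days (on this read-out higher numbers stand for an effect only at larger amounts of compound and lower numbers for an effect already at smaller amounts), the lowest of the three numbers recorded there. Its nearest neighbour is compound 1 `Cc1ccccc1-c1c(C)nn(-c2nc(-c3ccc(Cl)c(Cl)c3)c(SC(C)C)s2)c1C(=O)O` at 5500 nM, with an 8.3-fold lower number from compound 1 to compound 3 (0.92 log units; beyond the scatter); furthest away is compound 2 `COc1cncc(-c2c(C)nn(-c3nc(-c4ccc(Cl)c(Cl)c4)c(SC(C)C)s3)c2C(=O)O)c1` at 21000 nM, with a 32-fold lower number from compound 2 to compound 3 (1.50 log units; beyond the scatter), while compound 1 to compound 2 shows a 3.8-fold higher number from compound 1 to compound 2 (0.58 log units; beyond the scatter). Compound 4 `Cc1nn(-c2nc(-c3ccc(Cl)c(Cl)c3)c(SC(C)C)s2)c(C(=O)O)c1-c1cccc(Cl)c1C` keeps every atom of compound 3 and differs only in where the methyl sits on the pendant ring: 3-chloro-2-methylphenyl in place of 3-chloro-5-methylphenyl on an aromatic carbon. Going by the values given here, no measured step rearranges this ring in the same way. The nearest guide is compound 1, whose 2-methylphenyl arm sits well behind compound 3 in this assay, and compound 4 carries its methyl at that same position of the ring while retaining the chlorine. A step upward from compound 3 is therefore expected, though smaller than the change from compound 1 to compound 3. Compound 4 is estimated at 2000 nM in this assay, with a range of 600 nM to 7000 nM, which amounts to an expected 3.0-fold higher number from compound 3 to compound 4 (0.48 log units; beyond the scatter).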

Compound 4, half-maximal effective concentration: 5100 nM
Compound 4: the middle estimate sits 2.6-fold (0.41 log units) below what was measured; low and high end bracket the measured number.
By their numbers in this assay, from the lowest: compound 3; then compounds 4 and 1 (each within the scatter of the next); then compound 2.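

In this assay, the place of the methyl on the pendant ring alone carries a clear change, with a 7.7-fold higher number from compound 3 to compound 4 (0.89 log units; beyond the scatter), although the atoms stay the same. The chlorine brings no such separation on an arm with the methyl placed as in 3-chloro-2-methylphenyl, with a 1.1-fold lower number from compound 1 to compound 4 (0.03 log units; within the scatter), so the chlorine alone does not account for the standing of compound 3, while the 3-chloro-2-methylphenyl arm still reads better than the 5-methoxypyridin-3-yl arm, with a 4.1-fold lower number from compound 2 to compound 4 (0.61 log units; beyond the scatter). Nothing measured on hand explains why the place of the methyl matters here.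

As far as these compounds go, whether a plain phenyl arm, or an ethyl in place of the methyl, would read with compound 3 or with compound 4 stays open. So does whether the gap between these two compounds would persist with an amide in place of the carboxy group.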